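Acetyl in Place of Phenoxy on the Distal Ring

A few compounds are considered here, and "the series" means these few. Any claim that something is new, unique, unknown or untested is made for them only; others in the source may bear on it.

Three cyclohexyl carbamates share one core and differ only in the substituent on the second aromatic ring. In an assay on cell membranes for binding affinity to Fatty-acid amide hydrolase 1 (Rattus norvegicus) (on this read-out lower numbers stand for stronger inhibition and higher numbers for weaker inhibition), compound 1 `NC(=O)c1ccc(-c2cccc(OC(=O)NC3CCCCC3)c2)cc1` gives 5910 nM, compound 2 `O=C(NC1CCCCC1)Oc1cccc(-c2ccc(F)cc2)c1` gives 65 nM, and compound 3 `O=C(NC1CCCCC1)Oc1cccc(-c2cccc(Oc3ccccc3)c2)c1` gives 420 nM. Compound 3 thus stands second highest of the three numbers; its gap to compound 2 and its gap to compound 1 are both beyond the scatter. For the measured compounds named here, the single step between compounds that differ in one place is a 91-fold lower number from compound 1 to compound 2 (1.96 log units; beyond the scatter), so the exchange of a carbamoyl group for a fluorine moved the read-out a long way.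

Compound 4 `CC(=O)c1cccc(-c2cccc(OC(=O)NC3CCCCC3)c2)c1` differs from compound 3 in one place: acetyl in place of phenoxy on an aromatic carbon. Going by the values given here, no measured step concerns the phenoxy group itself, and none concerns an acetyl group, so only a 91-fold lower number from compound 1 to compound 2 (1.96 log units; beyond the scatter) bears on it, and only loosely, as a carbonyl-bearing substituent entering the same ring. Because compound 1 gives 5910 nM with such a group, the number for compound 4 is expected to rise beyond the scatter, though by less than that large step. Compound 4 is estimated at 1200 nM, with a range from 250 nM to 6000 nM. The estimated step is a 2.9-fold higher number from compound 3 to compound 4 (0.46 log units; beyond the scatter).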

Compound 4, half-maximal inhibitory concentration: 9.1 nM
The estimate for compound 4 lay 130-fold (2.12 log units) above the measured number; the measured number lies below the stated range.
By their numbers in this assay, from the lowest: compound 4; then compound 2; then compound 3; then compound 1.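

The step for this change, a 46-fold lower number from compound 3 to compound 4 (1.66 log units; beyond the scatter), shows that in this assay the phenoxy group and its six-membered aromatic ring are not needed at this aromatic carbon, meta to a large group: acetyl, which has no ring, takes its place and the number falls a long way. For the compounds shown here, the earlier step, a 91-fold lower number from compound 1 to compound 2 (1.96 log units; beyond the scatter), concerned an exchange of carbamoyl for fluoro and said nothing about this carbon, so this is the first direct reading of a change here, and it shows that a carbonyl-bearing group at this place can go with a low number. No measurement at hand explains why the exchange has so large an effect.

The compounds shown do not separate what the loss of phenoxy contributes from what the arrival of acetyl contributes, since a plain hydrogen, a methyl or a methoxy at this carbon would be needed to tell the two apart. They also leave open whether a longer chain such as propanoyl, or a nitrile or a carboxylic acid, would hold the low number at this same carbon.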